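Trihydroxy variant of a weak hydrazone series in PC-3 cells

The source may report more compounds than this note shows. Statements on the series, on what has been measured and on what is new or still open speak of the compounds shown alone.

Compound 1 `Cc1c(C(=O)N/N=C\c2cccc(O)c2O)oc2cccc(O)c12` gives 12200 nM in a functional assay on PC-3 cells (Homo sapiens) for inhibition; on this read-out higher numbers stand for weaker inhibition and lower numbers for stronger inhibition.
Compound 2 `Cc1c(C(=O)N/N=C\c2cc(F)ccc2O)oc2cccc(O)c12` gives 3170 nM in this assay.
Compound 3 `Cc1c(C(=O)N/N=C\c2ccc(O)cc2O)oc2cccc(O)c12` gives 14800 nM in this assay.

Compound 3 stands at the highest number of the three, though compound 1 sits within the scatter of it; compound 2 is the one clearly apart, as a 4.7-fold higher number from compound 2 to compound 3 (0.67 log units; beyond the scatter) shows. Compound 4 `Cc1c(C(=O)N/N=C\c2ccc(O)c(O)c2O)oc2cccc(O)c12` differs from compound 3 only by hydroxy in place of hydrogen on an aromatic carbon. Going by the values given here, the step most like it is the swap of one hydroxy position between the dihydroxy pair, where a 1.2-fold higher number from compound 1 to compound 3 (0.08 log units; within the scatter) stayed within the scatter; no measured step adds a third hydroxy. The expectation is therefore a step of about a 1.1-fold lower number from compound 3 to compound 4 (0.06 log units; within the scatter), that is none beyond the scatter. Compound 4 is estimated at 13000 nM, within 5000 nM to 35000 nM.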

Compound 4, half-maximal inhibitory concentration: >= 40000 nM
Compound 4: no number, only a limit; the forecaster's own chance of this, stated with the estimate: 10%; middle value at least 3.0-fold (0.48 log units) away from the limit.
By their numbers in this assay, from the lowest: compound 2; then compounds 1 and 3 (each within the scatter of the next). At a limit, above all of these: compound 4.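

Compound 4 carries no number, only a limit: the limit of >= 40000 nM in this assay, at which 1 of the 4 values shown sits.

Hydroxy in place of hydrogen on this aromatic carbon, ortho to two hydroxy groups, gives an at least 2.7-fold higher number from compound 3 to compound 4 (0.43 log units; beyond the scatter), and the same comparison from the other dihydroxy compound gives an at least 3.2-fold higher number from compound 1 to compound 4 (0.51 log units; beyond the scatter). Adding this third hydroxy therefore weakens inhibition beyond the scatter, a change that the earlier dihydroxy compounds, which differ only in where one hydroxy sits, did not show.

As far as these compounds go, how far the true value of compound 4 lies past its limit stays open. So does whether methoxy, chlorine or an amine on this aromatic carbon would weaken inhibition in the same way.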